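A few compounds are considered here, and "the series" means these few. Any claim that something is new, unique, unknown or untested is made for them only; others in the source may bear on it.

Working notes on the series. Compound 1 `CN(C)C1=Nc2ccccc2C(CC(=O)NCc2ccc(NS(=O)(=O)c3ccc(F)cc3)cc2)N1c1ccccc1` gives 430 nM in an assay on HEK293 cells for inhibition of Voltage-dependent T-type calcium channel subunit alpha-1G (Homo sapiens); on this read-out lower numbers stand for stronger inhibition and higher numbers for weaker inhibition. Compound 2 `COC(=O)CC1c2ccccc2N=C(Nc2ccccc2)N1CCCCCN` gives 9160 nM, and compound 3 `COC(=O)CC1c2ccccc2N=C(Nc2ccccc2)N1CCCCCNC(=O)OC(C)(C)C` gives 2270 nM. Going by the values given here, the only single-point step among the measured compounds is a 4.0-fold lower number from compound 2 to compound 3 (0.61 log units; beyond the scatter). Among the compounds with values here, compound 3 thus stands second highest of the three numbers, nearer to compound 2 than to compound 1; compound 1 shows a lower number than compound 3 but differs from it in more than one place, so no step between them is drawn.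

Compound 4 `CC(C)(C)OC(=O)NCCCCCN1C(Nc2ccccc2)=Nc2ccccc2C1CC(=O)NCc1ccccc1` differs from compound 3 in one place: benzylamino in place of methoxy on a carbonyl carbon. Within the data shown here, no measured step addresses this exchange. The step from compound 2 to compound 3 concerns the amine end of the chain and does not bear on the carbonyl substituent. Among the measured compounds shown here, compound 1, the one measured compound with an amide rather than a methyl ester at that carbonyl, gives 430 nM, but its further differences from compound 3 leave that number unattributed to the ester-to-amide change. The direction of the step is therefore open, with a slight lean toward a lower number. Compound 4 is expected at 1500 nM, with a range from 400 nM to 6000 nM, an estimated step of a 1.5-fold lower number from compound 3 to compound 4 (0.18 log units; within the scatter) that is not expected to exceed the scatter.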

Compound 4, half-maximal inhibitory concentration: 1200 nM
Estimate against measurement, compound 4: 1.3-fold (0.10 log units) above, within the range that was stated.
By their numbers in this assay, from the lowest: compound 1; then compounds 4 and 3 (each within the scatter of the next); then compound 2.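

In this assay, the exchange of methoxy for benzylamino on a carbonyl carbon amounts to a 1.9-fold lower number from compound 3 to compound 4 (0.28 log units; within the scatter), the first step read at this position, and it stays within the scatter. The methoxycarbonyl and benzylcarbamoyl forms are therefore not told apart on this read-out, even though the change brings in a six-membered aromatic ring of carbon only and a hydrogen-bond donor, with the rest of the structure unchanged. No measurement on hand offers an explanation for this result.

Going by these compounds, the step at the other end of the molecule, a 4.0-fold lower number from compound 2 to compound 3 (0.61 log units; beyond the scatter), stands on the methyl ester alone, so it remains open whether the same exchange of tert-butoxycarbonyl for hydrogen on the amine nitrogen would read alike with benzylcarbamoyl at the carbonyl carbon. Also open, on these data alone, is how a carboxylic acid, a primary amide or a longer phenethylamino chain on that carbonyl carbon would read in this assay, and whether a fluorine or a sulfonamide on the benzyl ring would separate the amide from the ester beyond the scatter.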